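Methoxyphenyl in place of fluorophenyl: expected clearance shift

The source may report more compounds than this note shows. Statements on the series, on what has been measured and on what is new or still open speak of the compounds shown alone.

Measured so far:
compound 1 `COc1ccc(-c2c(S(=O)(=O)c3cc(F)cc(F)c3)cnc3c(F)cccc23)cc1`: 2.59 mL/min
compound 2 `O=S(=O)(c1cccc(F)c1)c1cnc2c(F)cccc2c1-c1ccccc1F`: 0.21 mL/min

In an ADME assay on microsomes from liver (Homo sapiens) for metabolic stability, tested at 2.5 uM (on this read-out higher numbers stand for fast clearance and lower numbers for slow clearance), compound 2 gives 0.21 mL/min and stands lowest of the two; compound 1 gives 2.59 mL/min, a higher number beyond the usual scatter. Compound 3 `COc1ccc(-c2c(S(=O)(=O)c3cccc(F)c3)cnc3c(F)cccc23)cc1` is not yet measured. It differs from compound 2 in one place: 4-methoxyphenyl in place of 2-fluorophenyl on an aromatic carbon. Compound 1 carries the same 4-methoxyphenyl and gives 2.59 mL/min, so an upward step is expected for compound 3, estimated as a 5.7-fold higher number from compound 2 to compound 3 (0.76 log units; beyond the scatter). Compound 3 is expected at 1.2 mL/min, with a range from 0.4 mL/min to 3 mL/min.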

Compound 3, intrinsic clearance in a liver preparation (reported as CLH), per the amount of preparation that the assay uses: 2.48 mL/min
Compound 3: the middle estimate sits 2.1-fold (0.32 log units) below what was measured; measured number inside the range.
By their numbers in this assay, from the lowest: compound 2; then compounds 3 and 1 (each within the scatter of the next).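

In this assay, 4-methoxyphenyl in place of 2-fluorophenyl now stands as a single change on this aromatic carbon, with a 12-fold higher number from compound 2 to compound 3 (1.07 log units; beyond the scatter). With 4-methoxyphenyl present, hydrogen in place of fluoro gives a 1.0-fold lower number from compound 1 to compound 3 (0.02 log units; within the scatter), so this fluoro does not separate compound 1 from compound 3. Nothing measured here explains the size of the step.

Still open, as far as these compounds go, is whether the step follows from gaining the methoxy group or losing the 2-fluorophenyl. Phenyl, 4-fluorophenyl or 2-methoxyphenyl at this place would separate the two, and an aminophenyl would extend the comparison.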